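Swapping a pyrrole for a furan on an acrylonitrile scaffold

The source may hold more compounds than are shown below. What is called first, only, known or untested is meant among the compounds shown, and "the series" means these compounds.

Measured so far:
Compound 1, `N#C/C(=C\c1ccc(Cl)cc1)C(=O)c1ccc[nH]1`, 36000 nM
Compound 2, `N#C/C(=C\c1c(F)c(F)c(F)c(F)c1F)C(=O)c1ccc[nH]1`, 224000 nM
Compound 3, `N#C/C(=C\c1ccc[nH]1)C(=O)NCc1ccc(Cl)c(Cl)c1`, 85000 nM

These three compounds were tested in a functional assay on HT-29 cells (Homo sapiens) for inhibition, read by MTT assay, with a stated time of 72 h; on this read-out lower numbers stand for stronger inhibition of growth and higher numbers for weaker inhibition of growth. Compound 3 stands second highest of the three numbers: compound 1 gives a lower number and compound 2 a higher one, and both of these gaps lie beyond the usual scatter of the measurement. So compound 3 sits between its two neighbours, neither the weakest nor the strongest inhibitor of growth here.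

The next compound, compound 4, `N#C/C(=C\c1ccco1)C(=O)NCc1ccc(Cl)c(Cl)c1`, differs from compound 3 in one place: furan-2-yl in place of 1H-pyrrol-2-yl on a double-bonded chain carbon bound to a double-bonded chain carbon. Both rings are five-membered aromatic rings with one hetero atom, so the overall shape of the molecule stays much the same; what changes is that a hydrogen-bond donor leaves and a hydrogen-bond acceptor enters.

For the measured compounds named here, no measured pair in this set shows what such a swap does, so the expectation rests on the small size of the change alone. The expected step from compound 3 to compound 4 in this assay is a 1.2-fold higher number from compound 3 to compound 4 (0.07 log units; within the scatter), which is a modest move and may not exceed the scatter. Compound 4 is therefore estimated at 100000 nM, with a likely range from 40000 nM to 250000 nM.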

Compound 4, concentration for 50% growth inhibition: 20000 nM
For compound 4 the middle estimate is 5.0-fold (0.70 log units) above the measured one; measured number outside the range, below it.
By their numbers in this assay, from the lowest: compounds 4 and 1 (each within the scatter of the next); then compound 3; then compound 2.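

In this assay the exchange of 1H-pyrrol-2-yl for furan-2-yl gives a 4.3-fold lower number from compound 3 to compound 4 (0.63 log units; beyond the scatter) and shows that growth inhibition at this place, on a double-bonded chain carbon bound to a double-bonded chain carbon, depends on which of these two rings is present. The earlier compounds shown here could not show this, as no two of them differ in only one place, and here two rings with the same count of heavy atoms give numbers that lie clearly apart. The change replaces a hydrogen-bond donor with a hydrogen-bond acceptor, but no measurement at hand says why the number falls.

This single pair cannot separate losing the donor from gaining the acceptor or from any other difference between the two rings. Going by these compounds, a thiophen-2-yl ring or a 1-methylpyrrol-2-yl ring in the same place would help to pull these apart, and it remains open whether furan-2-yl would give a similar step on a compound with a different group in place of the 3,4-dichlorobenzyl amide.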